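Removing the fluoro from compound 3: cytotoxicity expectation

A few compounds are considered here, and "the series" means these few. Any claim that something is new, unique, unknown or untested is made for them only; others in the source may bear on it.

Three compounds of the series share one core and differ only on the phenyl ring of the styryl arm. In an ADME assay on HUVEC cells (Homo sapiens) for cytotoxicity, read by MTT assay, with a stated time of 24 h (on this read-out higher numbers stand for lower toxicity in this test and lower numbers for higher toxicity in this test), compound 1 `O=[N+]([O-])c1ccc(/C=C/c2nnc(-c3ccc4c(c3)OCCO4)o2)cc1` gives 299000 nM. In this assay compound 2 `Fc1ccc(/C=C/c2nnc(-c3ccc4c(c3)OCCO4)o2)cc1` gives 325000 nM. In this assay compound 3 `Fc1cccc(/C=C/c2nnc(-c3ccc4c(c3)OCCO4)o2)c1` gives 295000 nM. Compound 3 stands with both neighbours inside the usual scatter; no ordering among the three can be read from these numbers.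

Both recorded steps were flat: a 1.1-fold higher number from compound 1 to compound 2 (0.04 log units; within the scatter) and a 1.1-fold lower number from compound 2 to compound 3 (0.04 log units; within the scatter). Neither a swap of nitro for fluoro nor a move of the fluoro around the ring moved the read-out beyond the scatter.

Compound 4 `C(=C/c1nnc(-c2ccc3c(c2)OCCO3)o1)\c1ccccc1` is not yet measured. The change from compound 3 is hydrogen in place of fluoro on an aromatic carbon. Since the two related steps were flat, the step of a 1.0-fold higher number from compound 3 to compound 4 (0.01 log units; within the scatter) is expected to stay within the scatter. For compound 4 in this assay the estimated value is 300000 nM, with a range from 150000 nM to 600000 nM.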

Compound 4, half-maximal cytotoxic concentration: 209000 nM
The estimate for compound 4 lay 1.4-fold (0.16 log units) above the measured number, and the stated range covers the measured number.
By their numbers in this assay, from the lowest: compounds 4, 3, 1 and 2 (each within the scatter of the next).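

Removing the substituent from the phenyl ring altogether also stays flat in this assay: hydrogen in place of fluoro gives (a 1.4-fold lower number from compound 3 to compound 4 (0.15 log units; within the scatter)) and (a 1.6-fold lower number from compound 2 to compound 4 (0.19 log units; within the scatter)), and hydrogen in place of nitro gives (a 1.4-fold lower number from compound 1 to compound 4 (0.16 log units; within the scatter)). All three steps remain inside the scatter, so on this read-out the compounds carrying fluoro or nitro on this ring cannot be told apart from the phenyl compound 4. No measured property is available to interpret these small differences.

Going by these compounds, whether an amine, a carboxylic acid or a longer chain on this ring would take the number beyond the scatter stays open. Also open, on these data alone, is whether changes to the shared core would shift the number in this assay at all.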